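The source may hold more compounds than are shown below. What is called first, only, known or untested is meant among the compounds shown, and "the series" means these compounds.

Compound 3 `Cc1[nH]c(=O)n(C2CCCCC2)c1-c1ccc(CC(C)C)cc1` carries the highest of the three numbers in hand, yet in a functional assay on brain (Rattus norvegicus, strain Wistar) for inhibition (a lower number here means a stronger inhibitor, a higher number a weaker inhibitor), compound 3 gives 10900 nM, which sits close to its neighbours. Compound 1 `Cc1[nH]c(=O)n(C)c1-c1ccc(CC(C)C)cc1` gives 7800 nM in this assay, and compound 2 `CCCCCCCCCCc1ccc(-c2c(C)[nH]c(=O)n2C)cc1` gives 7900 nM, so all three lie within the usual scatter of one another. Within the data shown here, the one step measured, a 1.4-fold higher number from compound 1 to compound 3 (0.15 log units; within the scatter), concerns the group on the aromatic nitrogen and not the position changed here. Compound 4 `Cc1[nH]c(=O)n(C2CCCCC2)c1-c1ccc(Oc2ccccc2)cc1` differs from compound 3 only at the para position: phenoxy in place of isobutyl on an aromatic carbon. Among the measured compounds shown here, no measured step bears directly on this exchange; the pair compound 1 and compound 2 differs at the same place, and their values are alike, but no other para group has been tested. The expected step is therefore a 1.1-fold lower number from compound 3 to compound 4 (0.04 log units; within the scatter), that is, none beyond the scatter. Compound 4 is accordingly estimated at 10000 nM in this assay, with a range from 3000 nM to 35000 nM.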

Compound 4, half-maximal inhibitory concentration: 7900 nM
Estimate against measurement, compound 4: 1.3-fold (0.10 log units) above, and the stated range covers the measured number.
By their numbers in this assay, from the lowest: compounds 1, 2, 4 and 3 (each within the scatter of the next).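

In this assay, phenoxy in place of isobutyl on the aromatic carbon, para to a large group, gives a 1.4-fold lower number from compound 3 to compound 4 (0.14 log units; within the scatter). Among these compounds, this is the first step measured at this position, and it shows that, with cyclohexyl on the aromatic nitrogen, a group bringing a six-membered aromatic ring and an oxygen leaves the number within the scatter of the isobutyl compound. Nothing at hand offers an explanation for this result.

The compounds shown leave open whether an amine or a carboxylic acid on this aromatic carbon would move the number beyond the scatter. They also leave open whether phenoxy would read the same with methyl in place of cyclohexyl on the aromatic nitrogen.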